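The source may hold more compounds than are shown below. What is called first, only, known or untested is meant among the compounds shown, and "the series" means these compounds.

Measured compounds in a functional assay, read by spectrophotometry, with a stated time of 1 h; on this read-out higher numbers stand for weaker inhibition and lower numbers for stronger inhibition:
- compound 1, `NS(=O)(=O)CC(=O)N/N=C/c1cc2ccccc2[nH]c1=O`: 8730000 nM
- compound 3, `Cc1ccc2[nH]c(=O)c(/C=N/NC(=O)CS(N)(=O)=O)cc2c1`: 5830000 nM
- compound 2, `Cc1ccc2[nH]c(=O)c(/C=N/c3ccc(S(N)(=O)=O)cc3)cc2c1`: "not active" (no number reported)

Compound 1 and compound 3 share one core; compound 2 carries a different one, and the difference between the two cores is not broken down here. Within the first pair the single change is hydrogen in place of methyl on an aromatic carbon, and the step it made is a 1.5-fold higher number from compound 3 to compound 1 (0.18 log units; within the scatter). For the measured compounds named here, for compound 2 the assay reports no number, only that the compound is inactive.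

Compound 4, `NS(=O)(=O)c1ccc(/N=C/c2cc3ccccc3[nH]c2=O)cc1`, is not yet measured. It differs from compound 2 by hydrogen in place of methyl on an aromatic carbon, the same change as from compound 3 to compound 1, at a place described in the same words. Because the earlier step of a 1.5-fold higher number from compound 3 to compound 1 (0.18 log units; within the scatter) lies within the scatter, the step from compound 2 to compound 4 in this assay is expected to be small as well, so compound 4 is expected to sit where compound 2 sits, that is at the inactive end of this series. On that basis compound 4 is estimated at 30000000 nM, with a range from 8000000 nM to 120000000 nM, and a fair chance that again only a limit is reported.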

Compound 4, half-maximal inhibitory concentration: 266000 nM
The estimate for compound 4 lay 110-fold (2.05 log units) above the measured number; measured number below the stated range.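

In this assay, for the compounds shown here, compound 2 is reported as "not active" without a number, so no step from compound 2 to compound 4 can be read. The compounds shown leave open how far hydrogen in place of methyl on an aromatic carbon moves the number on the core of compound 4, which gives 266000 nM. No measured evidence bears on this result.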